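The compounds below may be only part of what the source reports. "The series", "measured", "known", "first", "only" and "open" are said of these compounds alone.

Measured compounds in an ADME assay on L02 cells (Homo sapiens) for cytotoxicity, read by MTT assay, with a stated time of 48 h; on this read-out lower numbers stand for stronger inhibition and higher numbers for weaker inhibition:
- Compound 1, `CN(CCC#N)C[C@H]1CN(c2ccc(-n3cc(-c4ccccn4)cn3)c(F)c2)C(=O)O1`, gives > 400 ug/mL, which is a limit of the assay rather than a number.
- Compound 2, `CCN1CCN(C[C@H]2CN(c3ccc(-n4cc(-c5ccccn5)cn4)c(F)c3)C(=O)O2)CC1`, gives 99 ug/mL.
- Compound 3, `O=C1CSC(=O)N1C[C@H]1CN(c2ccc(-n3cc(-c4ccccn4)cn3)c(F)c2)C(=O)O1`, gives > 400 ug/mL, again a limit of the assay and not a number.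

Compound 3 thus sits at the upper edge of what this assay can report, the same place where compound 1 sits, as noted in the limit of > 400 ug/mL in this assay, at which 2 of the 3 values shown sit. Among the measured compounds shown here, the one readable step among the three is an at least 4.0-fold higher number from compound 2 to compound 3 (0.60 log units; beyond the scatter), so swapping the piperazine group for the thiazolidinedione moved compound 3 toward weaker inhibition; the step that the two limits leave unreadable from compound 1 to compound 3 cannot be read because both ends are limits.

Compound 4, `O=C1O[C@@H](CSc2cccs2)CN1c1ccc(-n2cc(-c3ccccn3)cn2)c(F)c1`, differs from compound 3 by (thiophen-2-yl)sulfanyl in place of 2,4-dioxo-1,3-thiazolidin-3-yl on a saturated chain carbon bound to a saturated ring carbon. For the measured compounds named here, none of the measured steps involves a thiophenylsulfanyl group, so the only guide is that two of the three compounds already sit at the limit. The step of an at least 2.0-fold lower number from compound 3 to compound 4 (0.30 log units; that floor lies within the scatter) is therefore expected to be small or unreadable. Compound 4 is estimated at 200 ug/mL, within 50 ug/mL to 400 ug/mL.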

Compound 4, half-maximal inhibitory concentration: > 400 ug/mL
Compound 4: no number, only a limit; the forecaster's own chance of this, stated with the estimate: 50%; at least 2.0-fold (0.30 log units) between middle value and limit.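

In this assay compound 4 gives > 400 ug/mL, which is a limit of the assay and not a number. Among the compounds shown here, at this place on the saturated chain carbon, a (thiophen-2-yl)sulfanyl group, made of carbon and sulfur atoms only, gives the only readable new step, an at least 4.0-fold higher number from compound 2 to compound 4 (0.60 log units; beyond the scatter), so among the four compounds only the 4-ethylpiperazin-1-yl group of compound 2 gives a measured number. The steps linking compound 4 to compound 1 and compound 3 cannot be read, and the comparison stops at one edge of the assay: the limit of > 400 ug/mL in this assay, at which 3 of the 4 values shown sit.

Going by these compounds, how far compound 1, compound 3 and compound 4 lie beyond that limit stays open, so no order among them can be given. On these data alone, whether a morpholine ring, a primary amine or a carboxylic acid at this place would give a readable number also stays open.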